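Swapping the Amine Tail: Diethylamino to Piperazin-1-yl

A few compounds are considered here, and "the series" means these few. Any claim that something is new, unique, unknown or untested is made for them only; others in the source may bear on it.

Two measured compounds share one core and differ only in the amine at the far end of a three-carbon chain. Compound 1 `O=c1oc2cc(OCCCN3CCCCC3)ccc2s1` carries a piperidin-1-yl group, while compound 2 `CCN(CC)CCCOc1ccc2sc(=O)oc2c1` carries a diethylamino group. In a functional assay on the whole organism (strain albino) for inhibition, with Mus musculus as the target, with stated times of 30 min and 5 min, at a dose of 60 mg/kg by the intraperitoneal route (on this read-out higher numbers stand for more inhibition at the one dose given (going by the name of the read-out) and lower numbers for less inhibition), compound 1 gives 51.2%, and compound 2 gives 53.3%. The step of a number 2.1 percentage points higher from compound 1 to compound 2 (within the scatter) shows that exchanging one amine for the other left the read-out essentially unchanged. Compound 2 holds the higher of the two numbers, but compound 1 lies within the scatter of it, so no ranking between them is possible.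

Compound 3 `O=c1oc2cc(OCCCN3CCNCC3)ccc2s1` is the next step: piperazin-1-yl in place of diethylamino on a saturated chain carbon, three bonds along the chain from an oxygen on an aromatic ring. Among the measured compounds shown here, the only measured step that bears on this is the one from compound 1 to compound 2, which stayed within the scatter. The new change is of a different kind, since the entering ring brings a hydrogen-bond donor that neither earlier amine had, so the precedent is only partial.

Compound 3 is therefore expected to stay close to compound 2, with a step of a number 3.3 percentage points lower from compound 2 to compound 3 (within the scatter). The estimate for compound 3 is 50%, with a range from 30% to 68%.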

Compound 3, a percentage reported as inhibition, in the whole organism at one dose (the size of the read-out at that dose, not a potency): 62.3%
Estimate against measurement, compound 3: 12.3 percentage points below; the range from low to high includes it.
By their numbers in this assay, from the lowest: compounds 1, 2 and 3 (each within the scatter of the next, the first and the last beyond it).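

Among the compounds shown here, exchanging the amine at this position can matter: with piperazin-1-yl in place of piperidin-1-yl, this assay shows a step of a number 11.1 percentage points higher from compound 1 to compound 3 (beyond the scatter), the first step in this set to clear the usual scatter. The two rings differ in one place, as piperazin-1-yl carries a second ring nitrogen with a hydrogen on it where piperidin-1-yl has a carbon, so this pair gives the cleanest view of the change, though the step is modest. The open-chain comparison is less decisive, with a step of a number 9 percentage points higher from compound 2 to compound 3 (within the scatter), so piperazin-1-yl cannot be separated from diethylamino, and no measurement offered here explains either step.

Whether the hydrogen-bearing ring nitrogen itself accounts for the step stays open, and 4-methylpiperazin-1-yl or morpholin-4-yl on the same three-carbon chain would speak to that question. Also open, as far as these compounds go, is how the piperazin-1-yl group behaves on a longer chain, and since each number is the size of the effect at a single dose, these results say nothing firm about potency.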